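A few compounds are considered here, and "the series" means these few. Any claim that something is new, unique, unknown or untested is made for them only; others in the source may bear on it.

Among the measured compounds shown here, compound 3 `CC1(C)Oc2ccc(C#N)cc2[C@H](Nc2ccccc2)[C@H]1O` holds the only plain number among the three values so far: in a functional assay (aorta) with Rattus norvegicus as the target (on this read-out higher numbers stand for weaker inhibition and lower numbers for stronger inhibition), compound 3 gives 1200 nM. Compound 1 `CCOC(=O)CN(c1ccccc1)C1c2cc(C#N)ccc2OC(C)(C)C1O` reaches only a limit of the assay, as in this assay compound 1 gives > 30000 nM. Compound 2 `CCOC(=O)CN(c1ccccc1)[C@@H]1c2cc(C#N)ccc2OC(C)(C)[C@H]1O` likewise stops at a limit, since in this assay compound 2 gives > 30000 nM. Between them stands a step that the two limits leave unreadable from compound 1 to compound 2, which cannot be read because of the fact that one of compounds 1 and 2 is drawn with a defined configuration and the other without, at the place where they differ together with the limit of > 30000 nM in this assay, at which 2 of the 3 values shown sit.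

Compound 4 `CCCCOC(=O)CN(c1ccccc1)[C@H]1c2cc(C#N)ccc2OC(C)(C)[C@@H]1O` differs from compound 3 by (butoxycarbonyl)methyl in place of hydrogen on a nitrogen on an aromatic ring. For the measured compounds named here, no measured step follows this exact change. Going by the values given here, the only step on record, from compound 1 to compound 2, is of unreadable size, so it offers no number to carry over. What the data do show is the limit of > 30000 nM in this assay, at which 2 of the 3 values shown sit, and both compounds sitting there carry a substituent on the same nitrogen that compound 3 leaves bare. Compound 4 is therefore expected to move by a 25-fold higher number from compound 3 to compound 4 (1.40 log units; beyond the scatter) toward weaker inhibition in this assay, most likely ending at a limit. The estimate for compound 4 is 30000 nM, within 6000 nM to 150000 nM.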

Compound 4, half-maximal inhibitory concentration: 27000 nM
The estimate for compound 4 lay 1.1-fold (0.05 log units) above the measured number; the measured number falls inside the stated range.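

With compound 4, replacing hydrogen on this nitrogen on an aromatic ring finally has a readable size: (butoxycarbonyl)methyl in place of hydrogen gives a 23-fold higher number from compound 3 to compound 4 (1.35 log units; beyond the scatter) in this assay. Compounds 1 and 2 also carry a substituent on this nitrogen, but both stop at a limit of the assay, so no size could be read from them. Among the compounds shown here, the one readable change at this position is therefore large and runs toward weaker inhibition.

The compounds shown leave open whether the ester or the chain itself goes with this loss, as every substituent shown on this nitrogen carries an ester. A carboxylic acid on the same chain, or a plain butyl group on this nitrogen, would separate the two.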